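Swapping a sulfur-linked pyridine for a directly bound imidazole

The source may hold more compounds than are shown below. What is called first, only, known or untested is meant among the compounds shown, and "the series" means these compounds.

Of the compounds shown here, three sharing one core have been measured in a functional assay for inhibition of sodium/hydrogen exchanger (Oryctolagus cuniculus); on this read-out higher numbers stand for weaker inhibition and lower numbers for stronger inhibition. Compound 1 `CCSc1cc(C)c(C(=O)N=C(N)N)cc1S(C)(=O)=O` carries ethyl on the sulfur and in this assay gives 5.9 nM. Compound 2 `Cc1cc(Sc2cccc(Cl)c2)c(S(C)(=O)=O)cc1C(=O)N=C(N)N` gives 37 nM, and compound 3 `Cc1cc(Sc2ccncc2)c(S(C)(=O)=O)cc1C(=O)N=C(N)N` gives 13 nM. Compound 3 therefore stands second highest of the three numbers: the nearest is compound 1, with a 2.2-fold higher number from compound 1 to compound 3 (0.34 log units; beyond the scatter), and the furthest is compound 2, with a 2.8-fold lower number from compound 2 to compound 3 (0.45 log units; beyond the scatter). The step of a 6.3-fold higher number from compound 1 to compound 2 (0.80 log units; beyond the scatter) completes the picture; all three steps are modest.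

Compound 4 `Cc1cc(-n2ccnc2C)c(S(C)(=O)=O)cc1C(=O)N=C(N)N` is not yet measured. It differs from compound 3 as follows: 2-methyl-1H-imidazol-1-yl in place of (pyridin-4-yl)sulfanyl on an aromatic carbon. Both measured steps that reach compound 3 change only the group on the sulfur, whereas here the sulfur itself leaves and 2-methyl-1H-imidazol-1-yl is bound straight to the aromatic carbon. Among the measured compounds shown here, no measured step shows such a change, so the direction is uncertain, but the spread seen across compounds 1, 2 and 3 has been modest.

Compound 4 is therefore expected to give about 20 nM in this assay, a step of a 1.5-fold higher number from compound 3 to compound 4 (0.19 log units; within the scatter), most likely falling between 6 nM and 70 nM.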

Compound 4, half-maximal inhibitory concentration: 29 nM
Estimate against measurement, compound 4: 1.5-fold (0.16 log units) below; the measured number falls inside the stated range.
By their numbers in this assay, from the lowest: compound 1; then compound 3; then compounds 4 and 2 (each within the scatter of the next).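

Among the compounds shown here, compound 4 is the first at this position in which the sulfur link itself is gone, with 2-methyl-1H-imidazol-1-yl bound straight to the aromatic carbon ortho to the methylsulfonyl group. In this assay this change stays modest, as the step from the pyridine (a 2.2-fold higher number from compound 3 to compound 4 (0.35 log units; beyond the scatter)) and the step from the ethyl group (a 4.9-fold higher number from compound 1 to compound 4 (0.69 log units; beyond the scatter)) both show, so a sulfur atom at this place is not needed for a number in the same range as those of the sulfur-linked compounds. Against the chlorinated compound, the step (a 1.3-fold lower number from compound 2 to compound 4 (0.11 log units; within the scatter)) lies within the scatter, and nothing shown here accounts for that or for the other two steps.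

Because the sulfur and the ring leave together, the compounds shown do not separate the effect of losing the sulfur from that of exchanging a six-membered ring for a five-membered one. On these data alone, that would take a pyridin-4-yl bound directly to the aromatic carbon, or a 2-methylimidazole attached through sulfur, and the role of the methyl group on the imidazole stays open too, as would be tested by a plain 1H-imidazol-1-yl.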